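A Second Methoxy Group and Cell Growth Inhibition

This account rests on a few compounds, and the source may have more. Where it says the series, first, only, none or still open, it means among the compounds named here.

Compound 1 `COc1ccc(/C=C/C(=O)CC(C)=O)cc1OC` and compound 2 `COc1ccc(/C=C/C(=O)CC(C)=O)cc1` share one core and differ in a single place. In a functional assay on MCF7 cells (Homo sapiens) for cytotoxicity, read by MTT assay, with a stated time of 72 h (a lower number here means a stronger inhibitor, a higher number a weaker inhibitor), compound 2 gives 15800 nM, while compound 1 gives 10600 nM; the step of a 1.5-fold lower number from compound 2 to compound 1 (0.17 log units; within the scatter) comes from methoxy in place of hydrogen on an aromatic carbon. Compound 3 `Cc1cc(/C=C/c2ccc(O)cc2)on1` is built on a different core; how the two cores differ is not broken down here. In this assay compound 3 gives 50200 nM, the highest of the three numbers. Compound 4 `COc1cc(/C=C/c2cc(C)no2)ccc1O` is not yet measured. It differs from compound 3 by methoxy in place of hydrogen on an aromatic carbon, the same kind of change as from compound 2 to compound 1, though here the new group sits ortho to a hydroxy group rather than ortho to a methoxy group. The earlier step of a 1.5-fold lower number from compound 2 to compound 1 (0.17 log units; within the scatter) was small. A similarly small step is therefore expected, a 1.4-fold lower number from compound 3 to compound 4 (0.16 log units; within the scatter) in this assay. Compound 4 is estimated at 35000 nM, between 15000 nM and 80000 nM.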

Compound 4, half-maximal inhibitory concentration: 20900 nM
Estimate against measurement, compound 4: 1.7-fold (0.22 log units) above, and the stated range covers the measured number.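

In this assay, methoxy in place of hydrogen on an aromatic carbon gives a 2.4-fold lower number from compound 3 to compound 4 (0.38 log units; beyond the scatter). This step lies beyond the scatter and the earlier one within it, yet the gap between the two is small enough that the cores cannot be told apart in how they respond to this change: the same change on two cores in this assay, a 1.5-fold lower number (0.17 log units; within the scatter) from compound 2 to compound 1 and a 2.4-fold lower number (0.38 log units; beyond the scatter) from compound 3 to compound 4, 1.6-fold (0.21 log units) apart, within the scatter of two such steps. For the compounds shown here, with only two cores and one pair on each, this shows that the change carried over here, but it does not show that it would carry to any further core, nor why it has the size it has.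

The compounds shown leave open how other groups would compare at the same place, such as an amine, a chlorine atom or a longer chain like ethoxy. They also leave open whether the hydroxy group on compound 4 matters to the size of the step.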